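Solubility Along a Series of Aryl Groups on the Amide Nitrogen

The source may report more compounds than this note shows. Statements on the series, on what has been measured and on what is new or still open speak of the compounds shown alone.

Compound 1 `O=C(NCCCCc1ccccc1)c1cccc(C2SCC(=O)N2c2ccccn2)c1`: 20000 nM
Compound 2 `O=C(NCCCCc1ccccc1)c1cccc(C2SCC(=O)N2c2cccc(F)c2)c1`: 10000 nM
Compound 3 `CC(F)(F)c1cccc(N2C(=O)CSC2c2cccc(C(=O)NCCCCc3ccccc3)c2)c1`: 2000 nM

In a physicochemical assay for solubility, read by turbidimetry, measured as kinetic solubility, at pH 7.4 (on this read-out lower numbers stand for lower solubility and higher numbers for higher solubility), compound 3 stands lowest of the three, separated from the others by a 10-fold lower number from compound 1 to compound 3 (1.00 log units; beyond the scatter) and a 5.0-fold lower number from compound 2 to compound 3 (0.70 log units; beyond the scatter); compound 1 and compound 2 themselves differ only by a 2.0-fold lower number from compound 1 to compound 2 (0.30 log units; within the scatter). Compound 4 `O=C(NCCCCc1ccccc1)c1cccc(C2SCC(=O)N2c2ccc(C3CC3)cc2)c1` carries the change (a group of 9 heavy atoms (9 carbon; one three-membered non-aromatic ring of carbon only, one six-membered aromatic ring of carbon only) in place of a group of 10 heavy atoms (8 carbon, 2 fluorine; one six-membered aromatic ring of carbon only), on an amide-type nitrogen in a ring). The two steps that bear on it, from compound 1 and from compound 2 to compound 3, both replaced a smaller group on that nitrogen with a larger carbon-rich one and lowered the number; here one large carbon-rich group replaces another of similar size, so no move beyond the scatter is expected. Compound 4 is therefore estimated at 2000 nM, between 700 nM and 5000 nM. That estimate amounts to an expected step of no change at the digits printed from compound 3 to compound 4 (within the scatter).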

Compound 4, solubility: 2000 nM
The estimate for compound 4 equals the measured number at the digits printed; low and high end bracket the measured number.
By their numbers in this assay, from the lowest: compounds 3 and 4 (each within the scatter of the next); then compounds 2 and 1 (each within the scatter of the next).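

In this assay, 4-cyclopropylphenyl on the amide-type nitrogen gives no shift from the group it replaces (no change at the digits printed from compound 3 to compound 4 (within the scatter)), so two different large groups at this place, one with no fluorine, share one level. The gaps to the smaller groups remain (a 5.0-fold lower number from compound 2 to compound 4 (0.70 log units; beyond the scatter); a 10-fold lower number from compound 1 to compound 4 (1.00 log units; beyond the scatter)), so the low number of compound 3 is not confined to a fluorine-bearing group. As far as these compounds go, whether a 4-aminophenyl or 4-carboxyphenyl group on this nitrogen would bring the number back towards that of compound 1 stays open. Nothing measured here accounts for these numbers.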